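Aryl Thioether in Place of Aryl Ketone Chain, Melanocortin-4 Series

The source may report more compounds than this note shows. Statements on the series, on what has been measured and on what is new or still open speak of the compounds shown alone.

Measured compounds:
compound 1 `CC(C)C[C@H](N)c1cc(C(F)(F)F)ccc1N1CCN(C(=O)CCNC2CCCCC2)CC1`: 4800 nM
compound 2 `CC(C)C[C@H](N)c1cc(C(F)(F)F)ccc1N1CCN(C(=O)C(C)Cc2ccc(Cl)cc2O)CC1`: 36 nM
compound 3 `CC(C)C[C@H](N)c1cc(C(F)(F)F)ccc1N1CCN(C(=O)CCC(=O)c2ccc(Cl)cc2)CC1`: 820 nM

In an assay on HEK293 cells for displacement of a labelled ligand from Melanocortin receptor 4 (Homo sapiens) (a higher number here means a weaker inhibitor, a lower number a stronger inhibitor), compound 3 stands second highest of the three numbers. Its nearest neighbour is compound 1, with a 5.9-fold lower number from compound 1 to compound 3 (0.77 log units; beyond the scatter); its furthest is compound 2, with a 23-fold higher number from compound 2 to compound 3 (1.36 log units; beyond the scatter).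

Compound 4 `CC(C)C[C@H](N)c1cc(C(F)(F)F)ccc1N1CCN(C(=O)CSc2ccc(Cl)cc2Cl)CC1` has not yet been measured. Relative to compound 3 the change is (2,4-dichlorophenyl)sulfanyl in place of ((4-chlorophenyl)carbonyl)methyl on a saturated chain carbon bound to a carbonyl carbon. Going by the values given here, two measured steps bear on it. a 5.9-fold lower number from compound 1 to compound 3 (0.77 log units; beyond the scatter) is a modest step toward a lower number when an aryl ketone chain replaces the cyclohexylamino chain. a 23-fold higher number from compound 2 to compound 3 (1.36 log units; beyond the scatter) is a large step toward a higher number when that same aryl ketone chain replaces the branched 1-(4-chloro-2-hydroxybenzyl)ethyl, in which the aryl ring sits fewer bonds from the carbonyl. Compound 4 likewise places its aryl ring fewer bonds from the carbonyl, though compound 2 carries a hydroxyl that compound 4 does not. A lower number than compound 3 is therefore expected in this assay, of a size between the two measured steps. The expected step is a 5.5-fold lower number from compound 3 to compound 4 (0.74 log units; beyond the scatter). Compound 4 is estimated at 150 nM, with a range from 40 nM to 600 nM.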

Compound 4, inhibition constant: 1500 nM
The estimate for compound 4 lay 10-fold (1.00 log units) below the measured number; the whole stated range lies below it.
By their numbers in this assay, from the lowest: compound 2; then compounds 3 and 4 (each within the scatter of the next); then compound 1.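

In this assay, (2,4-dichlorophenyl)sulfanyl in place of ((4-chlorophenyl)carbonyl)methyl on a saturated chain carbon bound to a carbonyl carbon gives a 1.8-fold higher number from compound 3 to compound 4 (0.26 log units; within the scatter) and so leaves compounds 3 and 4 level at this position. An aryl ring fewer bonds from the carbonyl does not alone reproduce compound 2, as a 42-fold higher number from compound 2 to compound 4 (1.62 log units; beyond the scatter) shows, while a 3.2-fold lower number from compound 1 to compound 4 (0.51 log units; beyond the scatter) keeps compound 4 clear of the cyclohexylamino chain of compound 1. No measurement on hand accounts for the gap between compounds 2 and 4.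

Open, from the compounds shown here alone, is which part of 1-(4-chloro-2-hydroxybenzyl)ethyl carries that gap: the hydroxyl, the branch or the all-carbon link to the ring. A sulfone link, or a hydroxyl on the ring of the (2,4-dichlorophenyl)sulfanyl group, would begin to separate these.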